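The source may report more compounds than this note shows. Statements on the series, on what has been measured and on what is new or still open speak of the compounds shown alone.

Two nucleoside analogues have been tested for their ability to stop the growth of mouse lymphoma cells. In a functional assay on L5178Y cells (Mus musculus) for antiproliferative activity (on this read-out lower numbers stand for stronger inhibition and higher numbers for weaker inhibition), compound 1 `Cc1ccc(S(=O)(=O)O[C@@H]2[C@@H](O)[C@H](n3ccc(N)nc3=O)O[C@@H]2CO)cc1` gives 0.08 ug/mL, the higher of the two numbers recorded. Compound 2 `Nc1ccn(C2OC(CO)C(Br)C2O)c(=O)n1` reaches 0.03 ug/mL in this assay, a lower number than compound 1, and the gap between the two lies beyond the usual scatter of such measurements.

Compound 3 `Cc1ccc(S(=O)(=O)O[C@@H]2[C@@H](O)[C@H](n3cc(F)c(N)nc3=O)O[C@@H]2CO)cc1` has not yet been measured. Compared with compound 1 it carries a single change: fluoro in place of hydrogen on an aromatic carbon, sitting on an aromatic carbon of a six-membered aromatic ring with 2 nitrogen, ortho to an amino group. Among the measured compounds shown here, no measured pair shows this change directly, so its effect has to be expected rather than read off. A moderate move toward a lower number, somewhat beyond the scatter, seems likely as the step of a 2.7-fold lower number from compound 1 to compound 3 (0.43 log units; beyond the scatter). Compound 3 is therefore estimated at 0.03 ug/mL in this assay, within a range of 0.008 ug/mL to 0.15 ug/mL.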

Compound 3, concentration for 50% inhibition: 0.06 ug/mL
The estimate for compound 3 lay 2.0-fold (0.30 log units) below the measured number; the measured number falls inside the stated range.
By their numbers in this assay, from the lowest: compounds 2, 3 and 1 (each within the scatter of the next, the first and the last beyond it).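

Placing fluoro on this aromatic carbon, ortho to an amino group, gives a 1.3-fold lower number from compound 1 to compound 3 (0.12 log units; within the scatter) in this assay. At this position on the six-membered aromatic ring with 2 nitrogen, then, a single fluorine atom in place of hydrogen leaves the read-out indistinguishable from that of compound 1, so the swap is tolerated here. Nothing available explains this result.

Going by these compounds, whether the read-out would also hold with a bulkier or different group on the same carbon, such as a chlorine atom, a methyl group or an amine, remains open. On these data alone, it is also open whether fluoro would behave the same way in compound 2, whose bromine-bearing sugar differs from compound 1 in more than one place.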